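A few compounds are considered here, and "the series" means these few. Any claim that something is new, unique, unknown or untested is made for them only; others in the source may bear on it.

Measured in a functional assay on KYSE-70 cells for antiproliferative activity against KYSE-70 cell line (Homo sapiens), read by MTT assay, with a stated time of 72 h; a higher number here means a weaker inhibitor, a lower number a stronger inhibitor:
- Compound 1 `O=C(Nc1cccc(F)c1)c1cc(=O)[nH]c2cc(-c3ccsc3)ccc12`: 5100 nM
- Compound 2 `O=C(Nc1cccc(F)c1)c1cc(=O)[nH]c2cc(-c3ccccc3F)ccc12`: > 20000 nM

Compound 2 stands at the limit of > 20000 nM in this assay, at which 1 of the 2 values shown sits, so its value is a limit only. Compound 3 `O=C(Nc1cccc(F)c1)c1cc(=O)[nH]c2cc(-c3ccncc3)ccc12` differs from it as follows: pyridin-4-yl in place of 2-fluorophenyl on an aromatic carbon. Among the measured compounds shown here, the only measured step that bears on this change is an at least 3.9-fold higher number from compound 1 to compound 2 (0.59 log units; beyond the scatter), which shows that the group on this aromatic carbon can alter the read-out. A move back towards the value of compound 1 is therefore expected in this assay, of similar size but less certain, and with a lower number. The expected change is an at least 2.2-fold lower number from compound 2 to compound 3 (0.34 log units; beyond the scatter). For compound 3 the estimated value is 9000 nM, with an expected range of 3000 nM to 20000 nM.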

Compound 3, half-maximal inhibitory concentration: > 20000 nM
Compound 3 ended at the assay's limit; the forecaster's own chance of this, stated with the estimate: 30%; middle value at least 2.2-fold (0.34 log units) from the limit.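

In this assay, a second six-membered aromatic group at this aromatic carbon also falls short of thiophen-3-yl, with an at least 3.9-fold higher number from compound 1 to compound 3 (0.59 log units; beyond the scatter). Compound 3 gives > 20000 nM, a limit, and compound 2 also sits at a limit, so the step between them cannot be read, and the hydrogen-bond acceptor of pyridin-4-yl brings no measurable gain. Only compound 1 has a value inside the assay's range: the limit of > 20000 nM in this assay, at which 2 of the 3 values shown sit.

Going by these compounds, whether furan-3-yl or thiophen-2-yl would match or improve on thiophen-3-yl remains open. So does the effect of a non-aromatic group here, such as morpholine or a carboxylic acid.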